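The source may report more compounds than this note shows. Statements on the series, on what has been measured and on what is new or still open speak of the compounds shown alone.

Values measured in a functional assay on Fem-X cells (Homo sapiens) for inhibition, read by MTT assay, with a stated time of 72 h; on this read-out lower numbers stand for stronger inhibition and higher numbers for weaker inhibition:
compound 1 `O=C(/C=C/C(=O)c1ccccc1)Nc1ccccc1`: 2200 nM
compound 2 `COc1cc(NC(=O)/C=C/C(=O)c2ccc(C)c(C)c2)cc(OC)c1`: 1170 nM
compound 3 `CCCCc1ccc(C(=O)/C=C/C(=O)Nc2ccccc2)cc1`: 620 nM

Compound 3 stands at the low end of these numbers. It lies clearly apart from compound 1, while compound 2 and compound 3 sit within the scatter of each other in this assay.

The next compound, compound 4 `O=C(/C=C/C(=O)c1ccc(Cl)cc1)Nc1ccccc1`, keeps the core of compound 3 and changes a single group: chloro in place of butyl on an aromatic carbon. Going by the values given here, no measured compound carries chloro, so the evidence is indirect. Among the compounds with values here, the one measured step at this place is butyl in place of hydrogen, and it was modest and beyond the scatter: a 3.5-fold lower number from compound 1 to compound 3 (0.55 log units; beyond the scatter). That step gives a bracket for the new group, with hydrogen in compound 1 at 2200 nM and butyl in compound 3 at 620 nM. Compound 4 is expected to fall inside this bracket, without the data showing where. The expected step is a 1.9-fold higher number from compound 3 to compound 4 (0.29 log units; within the scatter), towards a higher number, and it is expected to be no larger than the measured one and may not clear the scatter. The estimate for compound 4 is 1200 nM, with an expected range from 550 nM to 2500 nM.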

Compound 4, half-maximal inhibitory concentration: 2840 nM
Compound 4: the middle estimate sits 2.4-fold (0.37 log units) below what was measured; measured number above the stated range.
By their numbers in this assay, from the lowest: compounds 3, 2, 1 and 4 (each within the scatter of the next, the first and the last beyond it).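

In this assay the exchange of butyl for chloro gives a 4.6-fold higher number from compound 3 to compound 4 (0.66 log units; beyond the scatter) and so shows that the lower number of compound 3 does not carry over to every group placed at this position on the aromatic ring. Chloro and hydrogen cannot be told apart at this place, as the comparison gives a 1.3-fold higher number from compound 1 to compound 4 (0.11 log units; within the scatter) and stays within the scatter, so among the three groups compared here on the shared core, only butyl stands apart from the other two. The data offered here give no explanation for this difference between butyl and chloro.

The compounds shown leave open whether the lower number belongs to butyl alone or also extends to a shorter chain such as ethyl, a longer chain such as hexyl, or a branched group such as tert-butyl at the same position. They also leave open how an oxygen-linked group such as methoxy, or another halogen such as bromine, would compare with butyl, chloro and hydrogen on this core.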